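Swapping thiophene for furan on the hydrazone carbon

This account rests on a few compounds, and the source may have more. Where it says the series, first, only, none or still open, it means among the compounds named here.

Compound 1, `CCCCC/C(C)=N/Nc1nc(-c2cccc(OC)c2)cs1`, gives 6720 nM in an assay on isolated protein for inhibition of Amine oxidase [flavin-containing] B (Homo sapiens), read by fluorescence; a lower number here means a stronger inhibitor, a higher number a weaker inhibitor.
Compound 2, `CCC/C(C)=N/Nc1nc(-c2cccc(OC)c2)cs1`, gives 871 nM in this assay.
Compound 3, `COc1cccc(-c2csc(N/N=C(\C)c3cccs3)n2)c1`, gives 551 nM in this assay.

Compound 3 stands at the lowest number of the three, but its gap to compound 2 is within the scatter, so the two cannot be ordered; only compound 1 is clearly separated, with a higher number.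

Compound 4, `COc1cccc(-c2csc(N/N=C(\C)c3ccco3)n2)c1`, is not yet measured. The change from compound 3 is furan-2-yl in place of thiophen-2-yl on a carbon with a double bond to nitrogen. The two measured steps that touch this same carbon are a 12-fold lower number from compound 1 to compound 3 (1.09 log units; beyond the scatter) and a 1.6-fold lower number from compound 2 to compound 3 (0.20 log units; within the scatter), both replacing an open chain by thiophen-2-yl. Neither compares one five-membered aromatic ring with another, so the data give no direct guide to the present swap. Both rings bring the same count of heavy atoms and the same count of acceptors, and the rest of the molecule is unchanged.

The expectation is therefore a step of about a 1.2-fold higher number from compound 3 to compound 4 (0.07 log units; within the scatter) in this assay, that is, no change beyond the scatter. Compound 4 is estimated at 650 nM, with a range from 220 nM to 2000 nM.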

Compound 4, half-maximal inhibitory concentration: 1680 nM
The estimate for compound 4 lay 2.6-fold (0.41 log units) below the measured number, and the stated range covers the measured number.
By their numbers in this assay, from the lowest: compounds 3, 2 and 4 (each within the scatter of the next, the first and the last beyond it); then compound 1.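

The two rings have the same count of heavy atoms and the same count of acceptors, and differ by sulfur against oxygen, yet in this assay the swap gives a 3.0-fold higher number from compound 3 to compound 4 (0.48 log units; beyond the scatter) on this carbon. Within the data shown here, the earlier steps replaced only an open chain by thiophen-2-yl, so this is the first sign that the position tells one five-membered aromatic ring from another. Against the open chains furan-2-yl behaves as thiophen-2-yl did, with a 4.0-fold lower number from compound 1 to compound 4 (0.60 log units; beyond the scatter) separating it from pentyl and a 1.9-fold higher number from compound 2 to compound 4 (0.29 log units; within the scatter) leaving it unresolved from propyl, while the data at hand offer no reason for the gap between the two rings.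

Still open, going by these compounds, is whether sulfur in the ring is what matters or whether thiophen-2-yl is a special case, which a thiazol-2-yl group or a plain phenyl ring on this carbon could help to settle. On these data alone, it is also open whether the gap between the two rings would persist if the methoxy group of the shared core gave way to another group, such as a chlorine atom or a hydroxyl group.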